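Compound 3: methoxy in place of difluoromethyl

The source may report more compounds than this note shows. Statements on the series, on what has been measured and on what is new or still open speak of the compounds shown alone.

Among the measured compounds shown here, in an ADME assay on microsomes from liver (Rattus norvegicus, strain Crj;CD(SD)) for metabolic stability, read by LC-MS, using NADPH, with a stated time of 30 min, tested at 0.1 uM (a higher number here means that more of the compound is left, a lower number that less of the compound is left), compound 1 `C[C@@]1(c2cc(NC(=O)c3cnc(OCF)cn3)ccc2F)C=C(CF)OC(N)=N1` gives 52% and compound 2 `C[C@@]1(c2cc(NC(=O)c3cnc(C(F)F)cn3)ccc2F)C=C(CF)OC(N)=N1` gives 44%, so compound 2 stands within the scatter of the only other measured compound. Compound 3 `COc1cnc(C(=O)Nc2ccc(F)c([C@]3(C)C=C(CF)OC(N)=N3)c2)cn1` carries methoxy in place of difluoromethyl on an aromatic carbon. For the measured compounds named here, the only measured step bearing on this change is a number 8 percentage points lower from compound 1 to compound 2 (within the scatter), with difluoromethyl in place of fluoromethoxy. On that evidence, no step beyond the scatter is expected in this assay, and the expected change is a number 2 percentage points lower from compound 2 to compound 3 (within the scatter). The estimate for compound 3 is 42%, with an expected range of 24% to 60%.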

Compound 3, percent of the compound remaining: 13%
Beside the measured number, compound 3's estimate is 29 percentage points above it; the whole stated range lies above it.
By their numbers in this assay, from the lowest: compound 3; then compounds 2 and 1 (each within the scatter of the next).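

In this assay, the group on this aromatic carbon now matters: methoxy in place of difluoromethyl gives a number 31 percentage points lower from compound 2 to compound 3 (beyond the scatter), and hydrogen in place of fluoro on the chain carbon bound to the oxygen gives a number 39 percentage points lower from compound 1 to compound 3 (beyond the scatter). The earlier swap between fluoromethoxy and difluoromethyl had shown no step beyond the scatter, so among these compounds only methoxy, the group without fluorine, stands apart. Nothing shown gives a reason for this drop. As far as these compounds go, whether trifluoromethoxy would keep or raise the percentage remaining stays open. So does whether ethoxy or a nitrile would behave like methoxy.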